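This account rests on a few compounds, and the source may have more. Where it says the series, first, only, none or still open, it means among the compounds named here.

Measured so far:
Compound 1 `O=C1N=C(N2CCOCC2)CN1c1ccc(Cl)cc1` gives 1.5 in a physicochemical assay for lipophilicity; a higher number here means a more lipophilic compound, a lower number a more polar compound
Compound 2 `CN(C)C1=NC(=O)N(c2ccc(Cl)cc2)C1` gives 1.6 in this assay

Among the compounds with values here, compound 1 stands level with the only other number. Within the data shown here, the single measured step is a number 0.10 log units higher from compound 1 to compound 2 (within the scatter) and it concerns dimethylamino in place of morpholin-4-yl on a carbon with a double bond to nitrogen. Compound 3 `O=C1N=C(N2CCOCC2)CN1c1ccc(Cl)c(Cl)c1` departs from compound 1 by chloro in place of hydrogen on an aromatic carbon. Among the measured compounds shown here, no measured step covers this change, so the size expected here rests on the structural change alone. A rise in this assay beyond the scatter is expected (estimated step: a number 0.60 log units higher from compound 1 to compound 3 (beyond the scatter)). Compound 3 is estimated at 2.1 (range 1.8 to 2.5).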

Compound 3, partition coefficient: 1.9
Compound 3: the middle estimate sits 0.20 log units above what was measured, and the stated range covers the measured number.
By their numbers in this assay, from the lowest: compounds 1, 2 and 3 (each within the scatter of the next, the first and the last beyond it).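

In this assay, chloro in place of hydrogen on an aromatic carbon, ortho to a chloro group and meta to a large group, gives a number 0.40 log units higher from compound 1 to compound 3 (beyond the scatter) on the core of compound 1. Unlike the single earlier step, which changed the group on the carbon with a double bond to nitrogen and stayed within the scatter, this aromatic change exceeds the scatter, though only modestly. Nothing available bears on why the step has this size.

From the compounds shown here alone, whether fluoro, methoxy or a carboxylic acid at this position would give a step of similar size remains open. Also open, going by these compounds, is whether chloro gives a similar step when dimethylamino replaces morpholin-4-yl, as in compound 2.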